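A Small Change at the Edge of Compound 3

The source may report more compounds than this note shows. Statements on the series, on what has been measured and on what is new or still open speak of the compounds shown alone.

Of the compounds shown here, three sharing one core have been tested in a functional assay on MDA-MB-231 cells (Homo sapiens) for inhibition, read by sulforhodamine B assay, tested at 10 uM; a lower number here means less inhibition, a higher number more inhibition at the concentration tested (going by the name of the read-out). Compound 1 `Cc1ccc(S(=O)(=O)N2N=C(c3ccc(N4CCN(C)CC4)cc3)CC2c2ccc(N(C)C)cc2)cc1` gives 10.7%. Compound 2 `CN1CCN(c2ccc(C3=NN(S(=O)(=O)c4ccc(Br)cc4)C(c4ccc(N(C)C)cc4)C3)cc2)CC1` gives 23.7%. Compound 3 `CN1CCN(c2ccc(C3=NN(S(=O)(=O)c4ccc(C(F)(F)F)cc4)C(c4ccc(N(C)C)cc4)C3)cc2)CC1` gives 12.1%, the second highest of the three numbers; its nearest neighbour is compound 1, within the scatter, while compound 2 sits beyond the scatter above it.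

Compound 4 `CN1CCN(c2ccc(C3=NN(S(=O)(=O)c4ccc(OC(F)(F)F)cc4)C(c4ccc(N(C)C)cc4)C3)cc2)CC1` differs from compound 3 in one place: trifluoromethoxy in place of trifluoromethyl on an aromatic carbon.

Every measured step among the three compounds changes a group on this same aromatic carbon, so all of them bear on the new step, though none of them involves a trifluoromethoxy group. The step of a number 1.4 percentage points higher from compound 1 to compound 3 (within the scatter) stayed within the scatter, whereas a number 13 percentage points higher from compound 1 to compound 2 (beyond the scatter) and a number 11.6 percentage points lower from compound 2 to compound 3 (beyond the scatter) were modest moves beyond it. The numbers at this position therefore span a narrow band, and a group not yet seen there cannot be placed with confidence on either side of compound 3.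

The expected step of a number 2.9 percentage points higher from compound 3 to compound 4 (within the scatter) is accordingly small, most likely within the scatter, and its direction is uncertain. Compound 4 is estimated at 15%, with a range from 5% to 28%.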

Compound 4, a percentage reported as inhibition, at one concentration (the size of the read-out at that concentration, not a potency): 10.6%
The estimate for compound 4 lay 4.4 percentage points above the measured number; the measured number falls inside the stated range.
By their numbers in this assay, from the lowest: compounds 4, 1 and 3 (each within the scatter of the next); then compound 2.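

In this assay, putting trifluoromethoxy in place of trifluoromethyl gives a number 1.5 percentage points lower from compound 3 to compound 4 (within the scatter), and the same group in place of methyl gives a number 0.1 percentage points lower from compound 1 to compound 4 (within the scatter), so three different groups on this aromatic carbon now sit within the scatter of one another. The extra oxygen of trifluoromethoxy, which adds one hydrogen-bond acceptor to the count, therefore leaves no readable mark on this number. Bromo alone stands apart from the other groups at this position, with the change from it to trifluoromethoxy being a number 13.1 percentage points lower from compound 2 to compound 4 (beyond the scatter), and nothing available here accounts for that difference.

The compounds shown leave open whether the separate place of compound 2 belongs to bromo alone or would be shared by a chloro or iodo group on the same carbon. They also leave open whether a group of another kind at this position, such as an amine, a carboxylic acid or a longer chain, would stay in the same band as compound 1, compound 3 and compound 4 or move clearly away from it.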